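A few compounds are considered here, and "the series" means these few. Any claim that something is new, unique, unknown or untested is made for them only; others in the source may bear on it.

In a functional assay on NCI-H460 cells (Homo sapiens) for inhibition, read by MTT assay, with a stated time of 24 h, tested at 0.1 ug/mL (a lower number here means less inhibition of growth, a higher number more inhibition of growth at the concentration tested), compound 2 `O=C(CCCCC(S)CCS)Nc1ccccc1` gives 5.5% and compound 3 `O=C(CCCCC(S)CCS)Nc1cccc(Cl)c1` gives 9.78%. Among the compounds with values here, these are the only two numbers available so far, and they lie within the scatter of each other, so compound 3 cannot be ranked apart from compound 2. A third relative, compound 1 `O=C(CCCCC1CCSS1)Nc1cccc(C(F)(F)F)c1`, is reported as "not active" (no number reported). That entry supplies no number to compare, although compound 1 also carries a trifluoromethyl group.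

The next compound to be tested in this assay is compound 4 `O=C(CCCCC(S)CCS)Nc1cccc(C(F)(F)F)c1`, which has not yet been measured. Its structure differs from that of compound 3 by one substitution: trifluoromethyl in place of chloro on an aromatic carbon. In plain words, trifluoromethyl takes the place of chloro on an aromatic carbon, while the rest of the molecule stays the same.

Within the data shown here, only one measured step bears on this change: a number 4.3 percentage points higher from compound 2 to compound 3 (within the scatter). That step replaced hydrogen with chloro at the same place and stayed within the scatter. No measured step starts from chloro, so this evidence is thin, but it gives no reason to expect a large move in either direction. The expected step, a number 0.2 percentage points higher from compound 3 to compound 4 (within the scatter), is therefore no larger than the scatter. The estimated value for compound 4 is 10%, within an expected range from 3% to 22%.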

Compound 4, percent growth inhibition at one concentration: 12%
Estimate against measurement, compound 4: 2 percentage points below; measured number inside the range.
By their numbers in this assay, from the lowest: compounds 2, 3 and 4 (each within the scatter of the next).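

Trifluoromethyl brings four heavy atoms to this aromatic carbon where chloro brought one, yet in this assay the swap gives a number 2.2 percentage points higher from compound 3 to compound 4 (within the scatter) and so cannot be told apart from no change. Set against the compound with plain hydrogen at the same carbon, the group gives a number 6.5 percentage points higher from compound 2 to compound 4 (within the scatter), so the two substituents tried here, chloro and trifluoromethyl, both leave the reading indistinguishable from that of the unsubstituted parent, even though they differ in size by the atom count. Nothing available explains why these three compounds read so closely together.

From the compounds shown here alone, it remains open whether a group of another kind on this carbon, such as an amine, a carboxylic acid or a methoxy group, would carry the number beyond the usual scatter, or whether changing the chain that links the amide to the two sulfur atoms would matter more than anything on the aromatic ring. All of these readings also come from a single low concentration, so any differences that might appear at higher concentrations cannot be judged from them.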